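Swapping the phenyl group on an amide-type nitrogen

A few compounds are considered here, and "the series" means these few. Any claim that something is new, unique, unknown or untested is made for them only; others in the source may bear on it.

Of the compounds shown here, three that share one core have been tested in a functional assay on A549 cells (Homo sapiens) for inhibition, read by CCK-8 assay, with a stated time of 72 h, tested at 1 uM; a higher number here means more inhibition of growth at the concentration tested, a lower number less inhibition of growth. Compound 1 `CN(C)C(=O)c1cc2cnc(Nc3ccc(NC(=O)C4(C(=O)Nc5ccc(F)cc5)CC4)cc3)nc2n1C1CCCC1`, with 4-fluorophenyl on an amide-type nitrogen, gives 86.6%. Compound 2 `Cc1cccc(NC(=O)C2(C(=O)Nc3ccc(Nc4ncc5cc(C(=O)N(C)C)n(C6CCCC6)c5n4)cc3)CC2)c1`, with 3-methylphenyl there, gives 35.2%. Compound 3 `CN(C)C(=O)c1cc2cnc(Nc3ccc(NC(=O)C4(C(=O)Nc5ccc(Cl)c(C(F)(F)F)c5)CC4)cc3)nc2n1C1CCCC1`, with 4-chloro-3-(trifluoromethyl)phenyl, gives 1.1%, the lowest of the three numbers.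

Compound 4 `CN(C)C(=O)c1cc2cnc(Nc3ccc(NC(=O)C4(C(=O)Nc5ccc(C(F)(F)F)cc5)CC4)cc3)nc2n1C1CCCC1` keeps everything else and carries 4-(trifluoromethyl)phenyl in place of 4-chloro-3-(trifluoromethyl)phenyl on that nitrogen: 4-(trifluoromethyl)phenyl in place of 4-chloro-3-(trifluoromethyl)phenyl on an amide-type nitrogen.

Going by the values given here, no measured step makes this exact swap, but all three measured steps change the same group, and all are large: a number 51.4 percentage points lower from compound 1 to compound 2 (beyond the scatter), a number 85.5 percentage points lower from compound 1 to compound 3 (beyond the scatter) and a number 34.1 percentage points lower from compound 2 to compound 3 (beyond the scatter). Changes at this place have therefore moved the number a long way in this small set. With compound 3 at 1.1%, there is almost no room for a further fall, so any clear movement should be upward. In this assay, the expected change is a number 38.9 percentage points higher from compound 3 to compound 4 (beyond the scatter), probably a large rise beyond the scatter, though its size is quite uncertain. For compound 4, the estimated value is 40%, with an expected range from 10% to 75%.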

Compound 4, percent growth inhibition at one concentration: -25.3%
Compound 4: the middle estimate sits 65.3 percentage points above what was measured, outside the stated range (below it).
By their numbers in this assay, from the lowest: compound 4; then compound 3; then compound 2; then compound 1.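

The step of a number 26.4 percentage points lower from compound 3 to compound 4 (beyond the scatter) shows that the number could still fall past compound 3: in this assay, compound 4 gives -25.3%, a negative reading, so the scale continues past the point where almost no growth inhibition is recorded. The sharpest contrast is the change of fluoro to trifluoromethyl on an aromatic carbon, which gives the largest step in this set (a number 111.9 percentage points lower from compound 1 to compound 4 (beyond the scatter)), so this position is highly sensitive to a single substituent swap; compound 4 also lies well under the 3-methylphenyl compound (a number 60.5 percentage points lower from compound 2 to compound 4 (beyond the scatter)). Nothing available explains why these groups rank in this order.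

On these data alone, with only four substituted phenyl groups on this nitrogen, it remains open whether an unsubstituted phenyl or a 4-chlorophenyl group would read closer to compound 1 or to compound 4. As far as these compounds go, it is also open whether a ring or chain carrying an amine or a carboxylic acid at this position would keep the reading of compound 1 (86.6%) or lose it.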